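Ethyl-to-methoxy swap on the sulfonate ester phenyl ring

A few compounds are considered here, and "the series" means these few. Any claim that something is new, unique, unknown or untested is made for them only; others in the source may bear on it.

Measured compounds:
compound 1 `CCc1ccccc1OS(=O)(=O)c1ccc(N2CCN(C)C2=O)cc1`, 2300 nM;
compound 2 `COc1ccccc1OS(=O)(=O)c1ccc(N2CCN(C)C2=O)cc1`, 21000 nM;
compound 3 `CCCN1CCN(c2ccc(S(=O)(=O)Oc3ccccc3CC)cc2)C1=O`, > 50000 nM.

In a functional assay on M21 cells (Homo sapiens) for antiproliferative activity, read by sulforhodamine B assay, with a stated time of 48 h (on this read-out higher numbers stand for weaker inhibition and lower numbers for stronger inhibition), compound 1 gives 2300 nM. Compound 2 differs by methoxy in place of ethyl on an aromatic carbon, and the step is a 9.1-fold higher number from compound 1 to compound 2 (0.96 log units; beyond the scatter). Compound 3 carries a different core, differing from compound 1 by ethyl in place of hydrogen on a saturated chain carbon bound to an amide-type nitrogen in a ring, with the step of an at least 21-fold higher number from compound 1 to compound 3 (1.33 log units; beyond the scatter). The value of compound 3 is a limit of this assay, not a number. Compound 4 `CCCN1CCN(c2ccc(S(=O)(=O)Oc3ccccc3OC)cc2)C1=O` is not yet measured; it differs from compound 3 by methoxy in place of ethyl on an aromatic carbon, the same change as from compound 1 to compound 2, at a place worded identically. Compound 4 is expected to sit at the same limit, a step that the limit leaves unreadable from compound 3 to compound 4, because compound 3 already rests at the limit of > 50000 nM in this assay, at which 1 of the 3 values shown sits, and the earlier step weakened inhibition. Estimated value for compound 4: 150000 nM, between 50000 nM and 500000 nM.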

Compound 4, half-maximal inhibitory concentration: > 100000 nM
Compound 4: no number, only a limit; the forecaster's own chance of this, stated with the estimate: 90%; the middle value is on the limit's open side.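

In this assay, methoxy in place of ethyl on the aromatic carbon gives a 9.1-fold higher number from compound 1 to compound 2 (0.96 log units; beyond the scatter), but on the core of compound 3 the same change cannot be read, as compound 3 and compound 4 both stand at limits and not at numbers. What can be read is the other change, ethyl in place of hydrogen on the saturated chain carbon, which now gives an at least 4.7-fold higher number from compound 2 to compound 4 (0.67 log units; beyond the scatter) and so weakens inhibition on both cores: the same change on two cores in this assay, an at least 21-fold higher number (1.33 log units; beyond the scatter) from compound 1 to compound 3 and an at least 4.7-fold higher number (0.67 log units; beyond the scatter) from compound 2 to compound 4; the limit leaves it open whether they differ. This does not show that the methoxy penalty carries over to the second core, nor that either step keeps its size there.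

Still open, going by these compounds, is whether any compound on the core of compound 3 gives a number rather than a limit in this assay. Also open, on these data alone, is how an amine or a carboxylic acid in place of ethyl or methoxy on the aromatic carbon would read.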